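The source may report more compounds than this note shows. Statements on the series, on what has been measured and on what is new or still open speak of the compounds shown alone.

Compound 1 `CNC(=O)c1cc(C(=O)N[C@H]2CC[C@H](O)CC2)n([C@@H](C)c2cccc(Cl)c2)n1` in a physicochemical assay for solubility, measured as kinetic solubility (a lower number here means a less soluble compound, a higher number a more soluble compound), sits at a limit of the assay, >= 143 ug/mL.
Compound 2 `CNC(=O)c1cc(C(=O)N[C@H]2[C@@H]3C[C@@H](O)C[C@@H]32)n([C@@H](C)c2cccc(Cl)c2)n1` gives 175 ug/mL.
Compound 3 `CNC(=O)c1cc(C(=O)N[C@H]2CC[C@H](O)CC2)c([C@@H](C)c2cccc(F)c2)o1` also sits at a limit, >= 63 ug/mL.

Compound 3 therefore stands only as a limit (the limit of >= 63 ug/mL in this assay, at which 1 of the 3 values shown sits), not as a number; of the three values shown, two are limits. For the measured compounds named here, the one measured step, a step that the limit leaves unreadable from compound 1 to compound 2, concerns the ring on an amide-type nitrogen and is itself unreadable, so it does not bear on the change to compound 4 `CNC(=O)c1cc(C(=O)N[C@H]2CC[C@H](O)CC2)c([C@@H](C)c2ccc(C)cc2)o1`. That change is 4-methylphenyl in place of 3-fluorophenyl on a saturated chain carbon bound to an aromatic carbon and a saturated chain carbon. With no readable step on this change, no step beyond the scatter is expected in either direction. Compound 4 is estimated at 80 ug/mL, range 30 ug/mL to 200 ug/mL, an expected step that the limit leaves unreadable from compound 3 to compound 4.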

Compound 4, solubility: >= 245 ug/mL
Compound 4 was reported as a limit; the forecaster's own chance of this, stated with the estimate: 40%; middle value at least 3.0-fold (0.48 log units) from the limit.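

Compound 3 and compound 4 both stand as limits in this assay, so no step can be read between them. The compounds shown leave open whether 4-methylphenyl and 3-fluorophenyl differ at all in this read-out.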